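Moving a hydroxyl on a terpyridine-like core

A few compounds are considered here, and "the series" means these few. Any claim that something is new, unique, unknown or untested is made for them only; others in the source may bear on it.

Measured so far:
compound 1, `Oc1ccc(-c2cc(-c3ccsc3)cc(-c3cccc(O)c3)n2)cc1`: 2230 nM
compound 2, `Oc1cccc(-c2cc(-c3ccccn3)cc(-c3ccccc3O)n2)c1`: 17100 nM

In a functional assay on DU-145 cells (Homo sapiens) for cytotoxicity, read by CCK-8 assay (a higher number here means a weaker inhibitor, a lower number a stronger inhibitor), compound 2 gives 17100 nM, the highest number of the two measured compounds. Compound 1 gives 2230 nM, and the gap between the two lies beyond the usual scatter. Compound 1 and compound 2 differ in more than one place, so their values alone cannot tell which part of the difference matters.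

Compound 3, `Oc1ccc(-c2cc(-c3ccccn3)cc(-c3cccc(O)c3)n2)cc1`, has not yet been measured. It differs from compound 2 in one place: 4-hydroxyphenyl in place of 2-hydroxyphenyl on an aromatic carbon. The hydroxyl is moved within the ring; nothing else changes.

Compound 3 is expected to come nearer to compound 1 because compound 1 also carries a 4-hydroxyphenyl group and gives 2230 nM. The change from compound 2 is expected to amount to a 3.4-fold lower number from compound 2 to compound 3 (0.53 log units; beyond the scatter), a step toward a lower number. Compound 3 is estimated at 5000 nM, with a range from 1500 nM to 17000 nM.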

Compound 3, half-maximal inhibitory concentration: 1980 nM
For compound 3 the middle estimate is 2.5-fold (0.40 log units) above the measured one, within the range that was stated.
By their numbers in this assay, from the lowest: compounds 3 and 1 (each within the scatter of the next); then compound 2.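

Swapping 2-hydroxyphenyl for 4-hydroxyphenyl on the aromatic carbon next to the ring nitrogen gives an 8.6-fold lower number from compound 2 to compound 3 (0.94 log units; beyond the scatter) in this assay, so at this position the place of the hydroxyl on the ring matters, even though no atom is gained or lost. The other single change, pyridin-2-yl in place of thiophen-3-yl, gives a 1.1-fold lower number from compound 1 to compound 3 (0.05 log units; within the scatter) in this assay, so with 4-hydroxyphenyl present these two rings cannot be told apart by this read-out. Nothing available here explains why the place of the hydroxyl makes this difference.

The compounds shown leave open what a 3-hydroxyphenyl group would give at this position, and how much the hydroxyl itself contributes. On these data alone, how an amine or a methoxy group in place of that hydroxyl would compare also remains unknown.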